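The source may report more compounds than this note shows. Statements on the series, on what has been measured and on what is new or still open speak of the compounds shown alone.

Measured so far in a functional assay on A549 cells (Homo sapiens) for antiproliferative activity, read by MTT assay, with a stated time of 48 h; on this read-out lower numbers stand for stronger inhibition and higher numbers for weaker inhibition:
- compound 1 `COc1ccc(-c2nnc(NC(=O)/C=C/c3ccc(F)cc3)s2)cc1`: 0.75 ug/mL
- compound 2 `O=C(/C=C/c1ccc(F)cc1)Nc1nnc(-c2ccccc2)s1`: 1.82 ug/mL
- compound 3 `Cc1ccc(-c2nnc(NC(=O)/C=C/c3ccc(F)cc3)s2)cc1`: 1.23 ug/mL

Compound 1 sits at the low end of this small set, but not clearly alone there: a 1.6-fold higher number from compound 1 to compound 3 (0.21 log units; within the scatter). Only one gap is clear: a 2.4-fold higher number from compound 1 to compound 2 (0.39 log units; beyond the scatter). The remaining comparison is a 1.5-fold lower number from compound 2 to compound 3 (0.17 log units; within the scatter).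

Compound 4 `COc1ccc(/C=C/C(=O)Nc2nnc(-c3ccc(OC)cc3)s2)cc1` departs from compound 1 elsewhere: methoxy in place of fluoro on an aromatic carbon. In words, this is methoxy in place of fluoro on an aromatic carbon, para to a large group. For the measured compounds named here, none of the measured steps changes this place, since all three act on the other aromatic ring, so they bear on it only indirectly. They do show that single swaps in this series have moved this assay modestly at most, as in a 2.4-fold higher number from compound 1 to compound 2 (0.39 log units; beyond the scatter). Going by the values given here, no sizeable step is therefore expected, and any shift beyond the scatter would be a surprise. The expected step is a 1.5-fold higher number from compound 1 to compound 4 (0.17 log units; within the scatter). For compound 4 the estimated value is 1.1 ug/mL, with an expected range from 0.4 ug/mL to 3.2 ug/mL.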

Compound 4, half-maximal inhibitory concentration: 0.52 ug/mL
Estimate against measurement, compound 4: 2.1-fold (0.33 log units) above; the range from low to high includes it.
By their numbers in this assay, from the lowest: compounds 4, 1, 3 and 2 (each within the scatter of the next, the first and the last beyond it).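

For the compounds shown here, the first change at this place, 4-fluorophenyl to 4-methoxyphenyl, does not separate the two compounds in this assay (a 1.4-fold lower number from compound 1 to compound 4 (0.16 log units; within the scatter)). Going by these compounds alone, the earlier steps all acted on the other aromatic ring, so this is the first direct sign that this aromatic carbon, para to a large group, can carry methoxy instead of fluoro without a step beyond the scatter. No measurement shown here offers an explanation for this result.

The compounds shown leave open how an amine, a carboxylic acid or a longer chain would read at this place, and how hydrogen would read there. Going by these compounds, they also show this swap only with methoxy on the other aromatic ring, so whether it reads the same with hydrogen or methyl on that ring remains open.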